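From 2,3-dichlorophenyl to 2,3,4-trimethoxyphenyl: an expected flat step

The compounds below may be only part of what the source reports. "The series", "measured", "known", "first", "only" and "open" are said of these compounds alone.

Measured in a functional assay on HeLa cells (Homo sapiens) for cytotoxicity, read by MTT assay, with a stated time of 72 h; on this read-out lower numbers stand for stronger inhibition and higher numbers for weaker inhibition:
- compound 1 `O=C(/C=C/c1cccc(Cl)c1Cl)Nc1cc2c(Nc3ccc(F)c(Cl)c3)ncnc2cc1O[C@H]1CCOC1`: 30500 nM
- compound 2 `COc1ccc(/C=C/C(=O)Nc2cc3c(Nc4ccc(F)c(Cl)c4)ncnc3cc2O[C@H]2CCOC2)c(OC)c1`: 26500 nM
- compound 3 `COc1cc2ncnc(Nc3ccc(F)c(Cl)c3)c2cc1NC(=O)/C=C/c1ccccc1[N+](=O)[O-]`: "not determined" (no result reported)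

Only two of these compounds carry a number. Among the measured compounds shown here, compound 1 and compound 2 lie within the scatter of each other, so compound 1 stands level with the only other measured value, and compound 3 offers no comparison.

Compound 4 `COc1ccc(/C=C/C(=O)Nc2cc3c(Nc4ccc(F)c(Cl)c4)ncnc3cc2O[C@H]2CCOC2)c(OC)c1OC` has not yet been measured. It keeps the core of compound 1 and changes one group: 2,3,4-trimethoxyphenyl in place of 2,3-dichlorophenyl on a double-bonded chain carbon bound to a double-bonded chain carbon. For the measured compounds named here, one measured step bears on this, a 1.2-fold lower number from compound 1 to compound 2 (0.06 log units; within the scatter), where 2,4-dimethoxyphenyl took the place of 2,3-dichlorophenyl at the same position. Going by the values given here, that step stayed within the scatter, and it is the only evidence available. No size of change beyond the scatter is therefore expected in this assay, and the estimated step is a 1.1-fold lower number from compound 1 to compound 4 (0.05 log units; within the scatter). For compound 4 the expected value is 27000 nM, with an estimated range from 13000 nM to 55000 nM.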

Compound 4, half-maximal inhibitory concentration: 4830 nM
For compound 4 the middle estimate is 5.6-fold (0.75 log units) above the measured one; the whole stated range lies above it.
By their numbers in this assay, from the lowest: compound 4; then compounds 2 and 1 (each within the scatter of the next).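

In this assay the group on this double-bonded chain carbon turns out to matter, with a 6.3-fold lower number from compound 1 to compound 4 (0.80 log units; beyond the scatter) when 2,3,4-trimethoxyphenyl replaces 2,3-dichlorophenyl, a change beyond the scatter that the step to the 2,4-dimethoxyphenyl of compound 2 had not shown. The difference between the two methoxy-bearing compounds is a single methoxy in place of hydrogen on an aromatic carbon, and it gives a 5.5-fold lower number from compound 2 to compound 4 (0.74 log units; beyond the scatter), so the gain appears only with this further methoxy and not with the exchange of chlorine for methoxy as such. Nothing available explains this step.

As far as these compounds go, whether a hydroxy or an amine in place of that methoxy would give a comparable number remains open. So does whether a phenyl carrying a single methoxy would stand with compound 2 or with compound 4.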